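The source may report more compounds than this note shows. Statements on the series, on what has been measured and on what is new or still open speak of the compounds shown alone.

Compound 1 `Cc1cc(Nc2cc(Cl)c(Cl)c(Cl)c2)nc(N)n1`, compound 2 `COc1ccc(-c2cc(Cl)cc(Nc3cc(C)nc(N)n3)c2)cc1`, compound 3 `Cc1cc(Nc2cc(Cl)cc(-c3ccc(C(F)(F)F)cc3)c2)nc(N)n1`.

In an assay on cells for inhibition of S-adenosylmethionine decarboxylase proenzyme (Homo sapiens), read by mass spectrometry, at pH 7.2 (a lower number here means a stronger inhibitor, a higher number a weaker inhibitor), compound 1 reaches only a limit, > 63000 nM. Compound 2 likewise gives only a limit, > 180000 nM. Compound 3 also gives only a limit, > 21000 nM. Compound 2 thus stands at a limit, and the two other values shown are limits as well. The step from compound 2 to compound 3, a step that the two limits leave unreadable from compound 2 to compound 3, cannot be read because of the limit of > 180000 nM in this assay, at which 1 of the 3 values shown sits, and (the limit of > 21000 nM in this assay, at which 1 of the 3 values shown sits). Compound 4 `Cc1cc(Nc2cc(Cl)cc(-c3cncnc3)c2)nc(N)n1` differs from compound 2 by pyrimidin-5-yl in place of 4-methoxyphenyl on an aromatic carbon. Among the compounds with values here, no measured step bears readably on this change, so no shift beyond the scatter can be foreseen. Compound 4 is therefore expected to give 150000 nM, between 30000 nM and 500000 nM, most likely again as a limit. For compound 4 the expected step is an at least 1.2-fold lower number from compound 2 to compound 4 (0.07 log units; that floor lies within the scatter).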

Compound 4, half-maximal inhibitory concentration: > 180000 nM
Compound 4: no number, only a limit (the forecaster's own chance of this, stated with the estimate: 85%); middle value at least 1.2-fold (0.07 log units) from the limit.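

In this assay compound 4 gives only a limit, > 180000 nM. No step from compound 2 to compound 4 can be read, because both stand at one limit: the limit of > 180000 nM in this assay, at which 2 of the 4 values shown sit.

The compounds shown leave open whether pyrimidin-5-yl or 4-methoxyphenyl gives the lower number, since none of them reaches a measured value.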